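Notes on the aryl swap from compound 1 to compound 3

The source may report more compounds than this note shows. Statements on the series, on what has been measured and on what is new or still open speak of the compounds shown alone.

compound 1 `CCc1cc(Nc2nc(N[C@@H](C)c3ncc(F)cn3)nc3cccc(F)c23)n[nH]1`: 230 nM
compound 2 `CCc1cc(Nc2nc(N[C@@H](C)c3ccc(Cl)cc3)nc3ccccc23)n[nH]1`: 70 nM

Of the compounds shown here, two have been measured in an assay on isolated protein for inhibition of G protein-coupled receptor kinase 6 (Homo sapiens), read by scintillation counting, radiometric assay and 33P incorporation, with a stated time of 80 min, in the presence of a further agent that is not named here; a lower number here means a stronger inhibitor, a higher number a weaker inhibitor. Compound 1 gives 230 nM, and compound 2 gives 70 nM. Compound 1 carries the higher of the two numbers; compound 2, its nearest neighbour, stands beyond the scatter on the lower side. Among the compounds with values here, compound 2 differs from compound 1 in more than one place, so these two values show only that the pair spans a gap, not what any single change contributes.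

Compound 3 `CCc1cc(Nc2nc(N[C@@H](C)c3ccc(C#N)cn3)nc3cccc(F)c23)n[nH]1` has not yet been measured. Its change from compound 1 is 5-cyanopyridin-2-yl in place of 5-fluoropyrimidin-2-yl on a saturated chain carbon bound to a nitrogen on an aromatic ring and a saturated chain carbon. Within the data shown here, no pair of measured compounds differs in this place alone, so there is no measured step to lean on. The expectation for this assay is a step of modest size, more likely toward a lower number than a higher one, though it may well stay within the scatter. Compound 3 is expected to give 130 nM, within 45 nM to 380 nM. That estimate corresponds to an expected step of a 1.8-fold lower number from compound 1 to compound 3 (0.25 log units; within the scatter).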

Compound 3, half-maximal inhibitory concentration: 91 nM
Compound 3: middle estimate off by 1.4-fold (0.15 log units), on the high side; low and high end bracket the measured number.
By their numbers in this assay, from the lowest: compounds 2 and 3 (each within the scatter of the next); then compound 1.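

Within the data shown here, this is the first step that can be read at a single place. On the saturated chain carbon bound to a nitrogen on an aromatic ring and a saturated chain carbon, with the rest of compound 1 unchanged, 5-cyanopyridin-2-yl in place of 5-fluoropyrimidin-2-yl gives a 2.5-fold lower number from compound 1 to compound 3 (0.40 log units; beyond the scatter) in this assay, so this position does respond to the aromatic group it carries, though modestly, and with the hydrogen-bond acceptor count the same on both sides. Nothing at hand accounts for the step, and within this one change the loss of a ring nitrogen, the loss of fluorine and the arrival of the nitrile cannot be told apart.

Still open, as far as these compounds go, is which of those differences carries the step, since compound 2 differs from both other compounds in more than one place and adds nothing to this reading. Also open, from the compounds shown here alone, is whether a primary carboxamide or a methoxy group in place of the nitrile would keep the number near that of compound 3, at 91 nM, or lose the gain over compound 1.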